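The source may hold more compounds than are shown below. What is called first, only, known or untested is meant among the compounds shown, and "the series" means these compounds.

Measured compounds:
compound 1, `COc1cc(N2C(N)=C(C#N)C(c3ccccc3Cl)C3=C2CC(C)(C)CC3=O)cc(OC)c1OC`: 20%
compound 2, `COc1cc(N2C(N)=C(C#N)C(/C=C/c3ccccc3)C3=C2CC(C)(C)CC3=O)cc(OC)c1OC`: 40%

In a functional assay on Ehrlich cells (Mus musculus) for cytotoxicity, tested at 100 ug/mL (on this read-out lower numbers stand for a weaker effect and higher numbers for a stronger effect at the one concentration tested), compound 1 gives 20%, while compound 2 gives 40%. Compound 2 therefore stands highest of the two numbers, and the step of a number 20 percentage points higher from compound 1 to compound 2 (beyond the scatter) lies beyond the scatter.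

Compound 3, `COc1cc(N2C(N)=C(C#N)C(c3ccc(C)o3)C3=C2CC(C)(C)CC3=O)cc(OC)c1OC`, differs from compound 2 in one place: 5-methylfuran-2-yl in place of 2-phenylethenyl on a saturated ring carbon. Among the measured compounds shown here, the only measured step concerns the same saturated ring carbon, where 2-phenylethenyl replaced 2-chlorophenyl, and it was modest, a number 20 percentage points higher from compound 1 to compound 2 (beyond the scatter). For the measured compounds named here, no measured step introduces a 5-methylfuran-2-yl, so the direction of the present change can only be inferred loosely. Because an aromatic ring at this position gave compound 1 its 20%, compound 3, which again carries an aromatic ring there, is expected to come out somewhat lower than compound 2, with an estimated 28% and a range from 12% to 45%. The expected step is a number 12 percentage points lower from compound 2 to compound 3 (beyond the scatter), modest and close to the scatter.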

Compound 3, a percentage reported as activity, at one concentration (the size of the read-out at that concentration, not a potency): 50%
Compound 3: the middle estimate sits 22 percentage points below what was measured; the measured number lies above the stated range.
By their numbers in this assay, from the lowest: compound 1; then compounds 2 and 3 (each within the scatter of the next).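

At this saturated ring carbon, in this assay, 5-methylfuran-2-yl in place of 2-phenylethenyl gives a number 10 percentage points higher from compound 2 to compound 3 (within the scatter), so the two groups cannot be told apart here, although one is a five-membered aromatic ring with an oxygen and the other a six-membered carbon ring with a double bond outside it. Set against 2-chlorophenyl, 5-methylfuran-2-yl gives a number 30 percentage points higher from compound 1 to compound 3 (beyond the scatter), which shows that an aromatic ring directly on this carbon does not in itself go with the low number of compound 1. Nothing given here explains the difference between these groups.

On these data alone, it remains open how much the methyl and the ring oxygen of 5-methylfuran-2-yl each contribute, and whether plain phenyl would read like 2-chlorophenyl. Also open, as far as these compounds go, is how a saturated group such as cyclohexyl, or a chain ending in an amine, would read at this carbon.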